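This account rests on a few compounds, and the source may have more. Where it says the series, first, only, none or still open, it means among the compounds named here.

Working notes on the series. In a functional assay for inhibition, with Rattus norvegicus as the target (on this read-out higher numbers stand for weaker inhibition and lower numbers for stronger inhibition), compound 1 (`CC(/N=c1\c(O)c(O)\c1=N/c1ccccc1)C(C)(C)C`) gives 5400 nM, and compound 2 (`CC(/N=c1\c(O)c(O)\c1=N/c1ccc(C#N)cc1)C(C)(C)C`) gives 520 nM, the lower of the two numbers. Among the compounds with values here, the only measured step, a 10-fold lower number from compound 1 to compound 2 (1.02 log units; beyond the scatter), came with cyano in place of hydrogen on an aromatic carbon.

Compound 3 (`CC(=O)c1ccc(/N=c2\c(O)c(O)\c2=N/C(C)C(C)(C)C)cc1`) has acetyl in place of cyano on an aromatic carbon, para to a large group: acetyl in place of cyano on an aromatic carbon. Within the data shown here, no measured step exchanges cyano for another group, so the evidence is indirect. Among the measured compounds shown here, the large step, a 10-fold lower number from compound 1 to compound 2 (1.02 log units; beyond the scatter), shows only that a change at this place can move the number in this assay substantially. A small rise is expected, with most of that large step retained.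

The expected step is a 1.7-fold higher number from compound 2 to compound 3 (0.24 log units; within the scatter). For compound 3 the estimated value is 900 nM, within an estimated range of 300 nM to 2700 nM.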

Compound 3, half-maximal inhibitory concentration: 21200 nM
Compound 3: middle estimate off by 24-fold (1.37 log units), on the low side; measured number outside the range, above it.
By their numbers in this assay, from the lowest: compound 2; then compound 1; then compound 3.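

Acetyl in place of cyano gave a 41-fold higher number from compound 2 to compound 3 (1.61 log units; beyond the scatter) in this assay, so the gain seen with cyano does not carry over to acetyl, even though each group counts one hydrogen-bond acceptor and no donor. Measured against the unsubstituted ring, acetyl also moves the number the opposite way from cyano, with a 3.9-fold higher number from compound 1 to compound 3 (0.59 log units; beyond the scatter): among these three compounds, a group on this aromatic carbon can raise or lower the number, and the direction depends on the group. No measured evidence bears on why the two groups differ.

From the compounds shown here alone, whether the rise extends to other carbonyl-bearing groups, such as a carboxylic acid or a primary amide, stays open. So does the outcome with a small group such as fluorine or methoxy at this place.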